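The compounds below may be only part of what the source reports. "The series", "measured", "known", "first", "only" and "open" are said of these compounds alone.

Of the compounds shown here, two have so far been tested in a functional assay on MDA-MB-436 cells (Homo sapiens) for antiproliferative activity, read by MTT assay, with a stated time of 48 h; a lower number here means a stronger inhibitor, a higher number a weaker inhibitor. Compound 1, `C=CS(=O)(=O)N1CCN(c2ncnc3sc(-c4cn(S(=O)(=O)c5ccccc5)c5ccccc45)cc23)CC1`, gives 38000 nM. Compound 2, `CN1CCN(c2ccc(-c3cc4c(N5CCN(C(=O)Nc6ccccc6)CC5)ncnc4s3)cc2)CC1`, gives 7090 nM, the lower of the two numbers and therefore the stronger inhibitor of the pair; its gap to compound 1 lies beyond the usual scatter of this measurement. Compound 3, `CC(C)c1cccc(C(C)C)c1NC(=O)N1CCN(c2ncnc3sc(-c4ccc(N5CCN(C)CC5)cc4)cc23)CC1`, has not yet been measured. It differs from compound 2 in one place: 2,6-diisopropylphenyl in place of phenyl on an amide-type nitrogen. Among the compounds with values here, with only two measured compounds, and no change of this kind between them, there is no earlier step of the same sort to lean on. For compound 3 a step of a 1.3-fold higher number from compound 2 to compound 3 (0.10 log units; within the scatter) is expected, meaning little movement beyond the scatter and, if anything, a slight weakening. Compound 3 is accordingly estimated at 9000 nM, with a likely range from 2500 nM to 30000 nM.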

Compound 3, half-maximal inhibitory concentration: 11300 nM
Beside the measured number, compound 3's estimate is 1.3-fold (0.10 log units) below it; measured number inside the range.
By their numbers in this assay, from the lowest: compounds 2 and 3 (each within the scatter of the next); then compound 1.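

In this assay, replacing phenyl with 2,6-diisopropylphenyl on the amide-type nitrogen gives a 1.6-fold higher number from compound 2 to compound 3 (0.20 log units; within the scatter), so this measurement cannot tell compound 2 and compound 3 apart. Within the data shown here, this is the first direct reading at this position, and it shows that the ring there can carry two isopropyl groups with no change in the number that stands out from the scatter. No measurement at hand speaks to why the number holds when this much carbon is added.

Going by these compounds, it remains open whether a different kind of group, such as an amine or a carboxylic acid on that ring, or a plain alkyl chain in place of the ring, would shift the number beyond the scatter. This single step also cannot show whether the same swap would behave alike on a different core.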